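The compounds below may be only part of what the source reports. "The series", "measured", "known", "first", "only" and "open" are said of these compounds alone.

Compound 1 `COc1cc(-c2cc(C(=O)/C=C/c3ccc(Cl)cc3)nc3cc(-c4ccccc4)nn23)cc(OC)c1OC`, compound 2 `COc1ccc(/C=C/C(=O)c2cc(-c3cc(OC)c(OC)c(OC)c3)n3nc(-c4ccccc4)cc3n2)cc1OC` and compound 3 `COc1ccc(C(=O)/C=C/c2cc(-c3cc(OC)c(OC)c(OC)c3)n3nc(-c4ccccc4)cc3n2)cc1OC` share a core carrying an unsaturated carbonyl chain and were tested in a functional assay on MDA-MB-231 cells (Homo sapiens) for antiproliferative activity, read by MTT assay, with a stated time of 24 h; on this read-out lower numbers stand for stronger inhibition and higher numbers for weaker inhibition. In this assay compound 1 gives 21600 nM, compound 2 gives 14200 nM and compound 3 gives 18300 nM; the three values all lie within the scatter of one another. Compound 2 and compound 3 have the same atoms joined differently, and the difference between the two cores is not broken down here. From compound 2 to compound 1 the change is 4-chlorophenyl in place of 3,4-dimethoxyphenyl on a double-bonded chain carbon bound to a double-bonded chain carbon, and the step is a 1.5-fold higher number from compound 2 to compound 1 (0.18 log units; within the scatter). Compound 4 `COc1cc(-c2cc(/C=C/C(=O)c3ccc(Cl)cc3)nc3cc(-c4ccccc4)nn23)cc(OC)c1OC` is not yet measured. It is reached from compound 3 by 4-chlorophenyl in place of 3,4-dimethoxyphenyl on a carbonyl carbon, the same kind of change as from compound 2 to compound 1 but at a different place: on a carbonyl carbon whose other neighbours are a double-bonded chain carbon, rather than on a double-bonded chain carbon bound to a double-bonded chain carbon. Because a 1.5-fold higher number from compound 2 to compound 1 (0.18 log units; within the scatter) stayed within the scatter, a similarly small step is expected: a 1.3-fold higher number from compound 3 to compound 4 (0.10 log units; within the scatter). Compound 4 is therefore estimated at 23000 nM in this assay, with an expected range from 11000 nM to 50000 nM.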

Compound 4, half-maximal inhibitory concentration: 32500 nM
Estimate against measurement, compound 4: 1.4-fold (0.15 log units) below, within the range that was stated.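

In this assay, 4-chlorophenyl in place of 3,4-dimethoxyphenyl on a carbonyl carbon gives a 1.8-fold higher number from compound 3 to compound 4 (0.25 log units; within the scatter), while 2-((4-chlorophenyl)carbonyl)ethenyl in place of (2-(4-chlorophenyl)ethenyl)carbonyl on an aromatic carbon gives a 1.5-fold higher number from compound 1 to compound 4 (0.18 log units; within the scatter). The exchange of 3,4-dimethoxyphenyl for 4-chlorophenyl reads the same on both cores, with no difference between the two steps that can be told from scatter: the same change on two cores in this assay, a 1.5-fold higher number (0.18 log units; within the scatter) from compound 2 to compound 1 and a 1.8-fold higher number (0.25 log units; within the scatter) from compound 3 to compound 4, 1.2-fold (0.07 log units) apart, within the scatter of two such steps. Going by these compounds alone, this shows only that the exchange stays small on both cores; since neither step rises above the scatter, it does not show that a real effect of the change carries from one core to the other, and two pairs say nothing about any further core.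

Still open, as far as these compounds go, is whether an aryl group bearing an amine or a carboxylic acid would move the number beyond the scatter on either core. Equally open, from the compounds shown here alone, is what a longer chain in place of the ethenyl and carbonyl link would do.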